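Tetrabromobenzotriazole Alcohols: From Methyl to 4-Fluorophenyl

The source may report more compounds than this note shows. Statements on the series, on what has been measured and on what is new or still open speak of the compounds shown alone.

Of the compounds shown here, two sharing a tetrabrominated core have been measured in a functional assay on MCF7 cells (Homo sapiens) for antiproliferative activity, read by MTT assay, with a stated time of 48 h, tested at 12.5 uM; on this read-out lower numbers stand for a stronger effect and higher numbers for a weaker effect at the one concentration tested. Compound 1, with the structure `OC(CCn1nc2c(Br)c(Br)c(Br)c(Br)c2n1)c1ccccc1`, gives 113% in this assay. Compound 2, with the structure `CC(O)CCn1nc2c(Br)c(Br)c(Br)c(Br)c2n1`, gives 79% in this assay. Within the data shown here, of the two numbers, compound 2 stands lowest, and the only step known is a number 34 percentage points lower from compound 1 to compound 2 (beyond the scatter), which describes methyl in place of phenyl on a saturated chain carbon bound to an oxygen on a saturated carbon and a saturated chain carbon.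

Compound 3, with the structure `OC(CCn1nc2c(Br)c(Br)c(Br)c(Br)c2n1)c1ccc(F)cc1`, has not yet been measured in this assay. It differs from compound 2 by 4-fluorophenyl in place of methyl on a saturated chain carbon bound to an oxygen on a saturated carbon and a saturated chain carbon. Among the measured compounds shown here, the single measured step bears directly on this change, as it reverses the exchange of a small group for an aromatic ring at the same place, and the fluorine is the only further difference. The step from compound 1 to compound 2 was large and downward, so the return to an aromatic ring is expected to move the number upward by a comparable amount, as a number 29 percentage points higher from compound 2 to compound 3 (beyond the scatter). Compound 3 is therefore estimated to give 108% in this assay, within a range from 85% to 130%.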

Compound 3, a percentage reported as activity, at one concentration (the size of the read-out at that concentration, not a potency): 109%
Beside the measured number, compound 3's estimate is 1 percentage points below it; the range from low to high includes it.
By their numbers in this assay, from the lowest: compound 2; then compounds 3 and 1 (each within the scatter of the next).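

In this assay the large difference at this position is not confined to the unsubstituted phenyl: the exchange of methyl for 4-fluorophenyl gives a number 30 percentage points higher from compound 2 to compound 3 (beyond the scatter) and so restores a number close to that of the phenyl compound. The fluoro in place of hydrogen on an aromatic carbon gives a number 4 percentage points lower from compound 1 to compound 3 (within the scatter) and therefore cannot be told apart from no change on this read-out. Among these three compounds, the aromatic ring at this place goes with the higher numbers, while compound 2, with methyl, stands apart from both, although that contrast still rests on a single small group set against two closely related rings.

No measurement at hand accounts for the difference between methyl and the two aromatic rings.

As far as these compounds go, it remains open whether ethyl, a longer chain or a cyclohexyl ring at this place would give numbers nearer to those of methyl or to those of the aromatic rings. Also open, from the compounds shown here alone, is what a methoxy group or an amine on the phenyl ring would do, and whether any such compound would fall lower than compound 2 does.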